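The source may report more compounds than this note shows. Statements on the series, on what has been measured and on what is new or still open speak of the compounds shown alone.

In a physicochemical assay for lipophilicity, read by HPLC, measured as octanol-water partition, at pH 7.4 (on this read-out higher numbers stand for higher lipophilicity and lower numbers for lower lipophilicity), compound 1 (`CC1(C)C[C@H](CN([C@H](CCC(F)(F)F)C(N)=O)S(=O)(=O)c2ccc(Cl)cc2)O1`) reads 3.8 and compound 2 (`NC(=O)[C@@H](CCC(F)(F)F)N(CC1CCCC1)S(=O)(=O)c1ccc(Cl)cc1`) reads 5.15 on the same scale. Compound 3 (`NC(=O)[C@@H](CCC(F)(F)F)N(CC1CCOCC1)S(=O)(=O)c1ccc(Cl)cc1`) reads 3.5 here, which puts it level with compound 1 (a number 0.30 log units lower from compound 1 to compound 3 (within the scatter)) and far from compound 2 (a number 1.65 log units lower from compound 2 to compound 3 (beyond the scatter)).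

Compound 4 (`NC(=O)[C@@H](CCC(F)(F)F)N(C[C@H]1COCCO1)S(=O)(=O)c1ccc(Cl)cc1`) has not been measured yet. It differs from compound 3 by one change (1,4-dioxan-2-yl in place of oxan-4-yl on a saturated chain carbon bound to a sulfonamide nitrogen), with 1,4-dioxan-2-yl in place of oxan-4-yl on a saturated chain carbon bound to a sulfonamide nitrogen.

For the measured compounds named here, no measured step makes exactly this swap, so the evidence is indirect. The closest guide is the large drop on going to oxan-4-yl from cyclopentyl (a number 1.65 log units lower from compound 2 to compound 3 (beyond the scatter)), a change from a ring with no hetero atom to a ring with one. The rise on going to cyclopentyl from 4,4-dimethyloxetan-2-yl (a number 1.35 log units higher from compound 1 to compound 2 (beyond the scatter)) points the same way. Compound 4 gains a second hetero atom in a ring that already has one, so a lower number is expected, though a smaller drop than those.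

The estimated change is a modest fall (a number 0.50 log units lower from compound 3 to compound 4 (beyond the scatter)). The expected value for compound 4 is 3 (estimated range 2.5 to 3.5).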

Compound 4, distribution coefficient: 2.75
Compound 4: middle estimate off by 0.25 log units, on the high side; the range from low to high includes it.
By their numbers in this assay, from the lowest: compound 4; then compounds 3 and 1 (each within the scatter of the next); then compound 2.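

In this assay, the read-out at this position, on a saturated chain carbon bound to a sulfonamide nitrogen, still responds when a six-membered ring that already holds 1 hetero atom gains a second one: the result is a number 0.75 log units lower from compound 3 to compound 4 (beyond the scatter). The earlier compounds showed only changes between differently sized rings, so this is the first step shown that keeps the ring size. Compound 4 also stands apart from both other compounds, with a number 2.40 log units lower from compound 2 to compound 4 (beyond the scatter) and a number 1.05 log units lower from compound 1 to compound 4 (beyond the scatter), whereas compound 1 and compound 3 lie within the scatter of each other.

Nothing measured here explains why the second ring oxygen gives this step. On these data alone, it also remains open how the opposite stereocentre of 1,4-dioxan-2-yl, an open methoxyethyl chain or a morpholin-2-yl ring, with an amine in the ring, would read at this position.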